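Methyl on the phenol oxygen: from compound 2 to compound 4

The source may hold more compounds than are shown below. What is called first, only, known or untested is meant among the compounds shown, and "the series" means these compounds.

Compound 2 `O=C(Nc1cccc(-n2cc(-c3ccncc3)c(-c3cc(O)cc(Cl)c3)n2)c1)Nc1ccc(Cl)c(Cl)c1` gives -38.1% in a functional assay on MDA-MB-231 cells (Homo sapiens) for inhibition, read by sulforhodamine B assay, with a stated time of 48 h, tested at 10 uM (a lower number here means a stronger effect, a higher number a weaker effect of the compound at the concentration tested), the highest of the three numbers seen. Compound 1 `O=C(Nc1cccc(-n2cc(-c3ccncc3)c(-c3cc(O)cc(Cl)c3)n2)c1)Nc1ccc(Cl)c(C(F)(F)F)c1` gives -47.3% in this assay, and the step of a number 9.2 percentage points higher from compound 1 to compound 2 (within the scatter) lies within the scatter. Within the data shown here, compound 3 `COc1cc(Cl)cc(-c2nn(-c3cccc(NC(=O)Nc4cc(C(F)(F)F)cc(C(F)(F)F)c4)c3)cc2-c2ccncc2)c1` gives -75% in this assay, a number beyond the scatter below compound 2, but compound 3 differs from compound 2 in two places at once, so no single measured step isolates either of those changes.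

Compound 4 `COc1cc(Cl)cc(-c2nn(-c3cccc(NC(=O)Nc4ccc(Cl)c(Cl)c4)c3)cc2-c2ccncc2)c1` differs from compound 2 by methyl in place of hydrogen on an oxygen on an aromatic ring. Among the measured compounds shown here, no measured step covers this change on its own; the only measured step, a number 9.2 percentage points higher from compound 1 to compound 2 (within the scatter), concerns a different position and is within the scatter. The lower number of compound 3, which also carries a methoxy group, hints at a lower number for compound 4, yet that hint cannot be separated from the second difference in compound 3. Compound 4 is therefore expected at -50%, within -85% to -20%. The step of a number 11.9 percentage points lower from compound 2 to compound 4 (beyond the scatter) is expected to be modest and uncertain in direction.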

Compound 4, a percentage reported as activity, at one concentration (the size of the read-out at that concentration, not a potency): -21%
The estimate for compound 4 lay 29 percentage points below the measured number; measured number inside the range.
By their numbers in this assay, from the lowest: compound 3; then compounds 1 and 2 (each within the scatter of the next); then compound 4.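

In this assay, among these compounds, capping the phenol oxygen gives the first single-change reading at this position: hydroxy to methoxy on the 3-chloro-5-hydroxyphenyl group gives a number 17.1 percentage points higher from compound 2 to compound 4 (beyond the scatter), so with the same dichlorophenyl urea the change weakens the effect at the concentration tested. The methoxy group therefore does not bring a low number by itself, since compound 4 carries it and still stands at the top of the four numbers, above compound 3 at -75%. Nothing shown accounts for the size or direction of this step.

From the compounds shown here alone, it remains open whether the same change would shift the number similarly with the trifluoromethyl-bearing urea of compound 1. Going by these compounds, it is also open how an ethoxy group, a longer chain on that oxygen, or an amine in place of the hydroxy would read here.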